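A few compounds are considered here, and "the series" means these few. Any claim that something is new, unique, unknown or untested is made for them only; others in the source may bear on it.

Of the compounds shown here, three from this series have been tested in a functional assay on cells (Cancer cell lines, Homo sapiens) for inhibition; on this read-out higher numbers stand for weaker inhibition of growth and lower numbers for stronger inhibition of growth. Compound 1 `Cc1cc(-c2nc3sc(C)cn3c2/C=N/NC(=N)N)c(C)s1` gives 3720 nM, and compound 2 `Cc1cn2c(/C=N/NC(=N)N)c(-c3ccsc3)nc2s1` gives 5370 nM. Compound 3 `N=C(N)N/N=C/c1c(-c2ccsc2)nc2n1CCS2` is built on a different core and gives 22900 nM, the highest number of the three; how its core differs from that of compound 2 is not broken down here.

Compound 1 and compound 2 differ in one place, (2,5-dimethylthiophen-3-yl in place of thiophen-3-yl on an aromatic carbon), and this change produced a 1.4-fold lower number from compound 2 to compound 1 (0.16 log units; within the scatter).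

Compound 4 `Cc1cc(-c2nc3n(c2/C=N/NC(=N)N)CCS3)c(C)s1` has not yet been measured. It stands to compound 3 as compound 1 stands to compound 2: the difference is 2,5-dimethylthiophen-3-yl in place of thiophen-3-yl on an aromatic carbon. The surroundings of the place are not identical, since in compound 3 and compound 4 the place is also two ring bonds from two ring atoms that each bear a fused ring, so this is the same kind of change rather than the same change.

On the evidence of compound 2 and compound 1, where the step was a 1.4-fold lower number from compound 2 to compound 1 (0.16 log units; within the scatter), the step from compound 3 to compound 4 is expected to be small as well, roughly a 1.4-fold lower number from compound 3 to compound 4 (0.16 log units; within the scatter). Among the measured compounds shown here, compound 4 is therefore estimated to give about 16000 nM in this assay, with a plausible range from 7000 nM to 35000 nM, the wide range reflecting that only one earlier example of this change, on a different core, is available.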

Compound 4, concentration for 50% growth inhibition: 13800 nM
The estimate for compound 4 lay 1.2-fold (0.06 log units) above the measured number, within the range that was stated.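

In this assay, among the compounds shown here, putting 2,5-dimethylthiophen-3-yl in place of thiophen-3-yl on the second core gave a 1.7-fold lower number from compound 3 to compound 4 (0.22 log units; within the scatter), so here too the change produced no step that can be told apart from repeat measurement. Set side by side, the two steps agree: the same change on two cores in this assay, a 1.4-fold lower number (0.16 log units; within the scatter) from compound 2 to compound 1 and a 1.7-fold lower number (0.22 log units; within the scatter) from compound 3 to compound 4, 1.1-fold (0.06 log units) apart, within the scatter of two such steps. For the compounds shown here, this shows that, on these two cores, the change carried over as a step too small to read, but it rests on only two pairs of compounds, does not show that the change would behave the same way on any other core, and gives no ground for claiming a real difference within either pair.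

The compounds shown carry only thiophen-3-yl or 2,5-dimethylthiophen-3-yl at this place, which leaves open whether a group of another kind there, such as an amine, a carboxylic acid or a longer chain, would shift the number beyond the scatter. On these data alone, it also remains open whether the near absence of a step would hold in any read-out other than this assay.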